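Vinylsulfonamide replacing a sulfonamidomethyl on the thiourea series

A few compounds are considered here, and "the series" means these few. Any claim that something is new, unique, unknown or untested is made for them only; others in the source may bear on it.

Measured so far in an assay on CHO cells for binding affinity to transient receptor potential cation channel subfamily V member 1 (Rattus norvegicus); on this read-out higher numbers stand for weaker inhibition and lower numbers for stronger inhibition:
compound 1 `CC(C)(C)c1ccc(C/N=C(\S)NCc2cccc(NS(C)(=O)=O)c2)cc1`, 6000 nM
compound 2 `CC(C)(C)c1ccc(C/N=C(\S)NCc2ccc(CNS(C)(=O)=O)cc2)cc1`, 6120 nM
compound 3 `CC(C)(C)c1ccc(C/N=C(\S)NCc2cccc(S(C)(=O)=O)c2)cc1`, 1000 nM

Compound 2 gives the highest number of the three in this assay. Its nearest neighbour is compound 1, whose value lies within the scatter of that of compound 2, so the two cannot be ordered; compound 3 stands apart from both, with a lower number beyond the scatter.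

The next compound is compound 4 `C=CS(=O)(=O)Nc1ccc(CN/C(S)=N/Cc2ccc(C(C)(C)C)cc2)cc1`. It differs from compound 2 in one place: (vinylsulfonyl)amino in place of (methanesulfonamido)methyl on an aromatic carbon.

Among the compounds with values here, only one measured step bears on this change, and only in part: a 6.0-fold lower number from compound 1 to compound 3 (0.78 log units; beyond the scatter), where the sulfonamide nitrogen was removed and a plain methylsulfonyl remained. Compound 4 keeps a sulfonamide, so that step is not a direct match. Compounds 1 and 2, which both carry a methanesulfonamide, show values within the scatter of each other, which suggests that moving such a group onto the ring itself changes little. Within the data shown here, with no measured precedent for the vinyl group, a small or no step beyond the scatter is expected.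

Compound 4 is therefore estimated at 4000 nM, range 1200 nM to 12000 nM, an expected step of a 1.5-fold lower number from compound 2 to compound 4 (0.18 log units; within the scatter).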

Compound 4, inhibition constant: 231 nM
Compound 4: the middle estimate sits 17-fold (1.24 log units) above what was measured; the measured number lies below the stated range.
By their numbers in this assay, from the lowest: compound 4; then compound 3; then compounds 1 and 2 (each within the scatter of the next).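

In this assay, the replacement of (methanesulfonamido)methyl by (vinylsulfonyl)amino on an aromatic carbon, para to a large group, gives a 26-fold lower number from compound 2 to compound 4 (1.42 log units; beyond the scatter). Within the data shown here, the only lower number among the earlier compounds came with a 6.0-fold lower number from compound 1 to compound 3 (0.78 log units; beyond the scatter), a change that removes the sulfonamide nitrogen, whereas compound 4 keeps a sulfonamide, so a large drop in the number does not depend on losing that nitrogen. The leaving and entering groups match in heavy atoms, hydrogen-bond donors and hydrogen-bond acceptors and differ in the count of double bonds outside aromatic rings, but no measurement at hand accounts for the size of the step.

This single change joins two differences, the loss of the methylene link to the ring and vinyl in place of methyl on the sulfonyl, and the compounds shown do not separate them. On these data alone, whether the vinyl group itself carries the step remains open, and an ethanesulfonamido group or a methanesulfonamido group in the same place on the shared core would bear directly on that question.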